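Nitro Replaced by Trifluoromethyl on a Shared Amide Core

The source may report more compounds than this note shows. Statements on the series, on what has been measured and on what is new or still open speak of the compounds shown alone.

Measured compounds:
compound 1, `COc1ccc2sc(NC(=O)c3ccc(C)cc3)nc2c1`, > 10 ug/mL
compound 2, `COc1ccc2sc(NC(=O)c3ccc([N+](=O)[O-])cc3)nc2c1`, > 10 ug/mL

Compound 1 `COc1ccc2sc(NC(=O)c3ccc(C)cc3)nc2c1` was examined in a functional assay on NUGC-3 cells (Homo sapiens) for antiproliferative activity, read by sulforhodamine B assay; a lower number here means a stronger inhibitor of growth, a higher number a weaker inhibitor of growth. In this assay compound 1 returns only a limit, > 10 ug/mL, not a number. Compound 2 `COc1ccc2sc(NC(=O)c3ccc([N+](=O)[O-])cc3)nc2c1` stands at the same kind of mark. In this assay compound 2 also returns only a limit, > 10 ug/mL. Within the data shown here, the one measured step, a step that the two limits leave unreadable from compound 1 to compound 2, is therefore unreadable in size and direction, the reason being (the limit of > 10 ug/mL in this assay, at which 2 of the 2 values shown sit).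

Compound 3 `COc1ccc2sc(NC(=O)c3ccc(C(F)(F)F)cc3)nc2c1` is the unmeasured member. It differs from compound 2 as follows: trifluoromethyl in place of nitro on an aromatic carbon. Among the measured compounds shown here, the only step that bears on this change is the unreadable one from compound 1 to compound 2, so nothing measured here allows a directed expectation; compound 2 stands at the limit, and no movement beyond the scatter can be read from the data.

Compound 3 is therefore expected to sit near the same limit, with an estimated step that the limit leaves unreadable from compound 2 to compound 3. Compound 3 is estimated at 15 ug/mL, with a range from 5 ug/mL to 40 ug/mL.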

Compound 3, concentration for 50% growth inhibition: > 10 ug/mL
Compound 3: a limit, no number; the forecaster's own chance of this, stated with the estimate: 70%; the middle value is on the limit's open side.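

Compound 3 also returns only a limit in this assay, so no step among compound 1, compound 2 and compound 3 can be read in size or direction, because all three stand at one mark: the limit of > 10 ug/mL in this assay, at which 3 of the 3 values shown sit.

The compounds shown leave open whether methyl, nitro and trifluoromethyl on the shared core differ at all in growth inhibition.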